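This account rests on a few compounds, and the source may have more. Where it says the series, first, only, none or still open, it means among the compounds named here.

Measured so far:
compound 1, `C=C(C)C(=O)Nc1cc2c(N3CCc4ccccc43)ncnc2cc1OC`, 4830 nM;
compound 2, `C=C(C)C(=O)Nc1cc2c(N3CCc4ccccc43)ncnc2cc1O[C@@H]1CCOC1`, 4910 nM;
compound 3, `COc1cc2ncnc(N3CCCc4ccccc43)c2cc1NC(=O)/C=C/CN(C)C`, 1750 nM.

All three were tested in a functional assay on PC-3 cells (Homo sapiens) for antiproliferative activity, read by MTT assay, with a stated time of 72 h; a lower number here means a stronger inhibitor, a higher number a weaker inhibitor. Compound 1 and compound 2 share one core, and the change between them is oxolan-3-yl in place of methyl on an oxygen on an aromatic ring. This gave a 1.0-fold higher number from compound 1 to compound 2 (0.01 log units; within the scatter), so the two values cannot be told apart. Compound 3 has a different core and a different amide; the difference between the two cores is not broken down here. Compound 3 gives the lowest of the three numbers in this assay, and its gap to compound 1 and compound 2 lies beyond the scatter.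

Compound 4, `CN(C)C/C=C/C(=O)Nc1cc2c(N3CCCc4ccccc43)ncnc2cc1O[C@@H]1CCOC1`, is still to be measured. It differs from compound 3 by oxolan-3-yl in place of methyl on an oxygen on an aromatic ring, the same change as from compound 1 to compound 2, made at the same kind of place. Because that earlier change gave a 1.0-fold higher number from compound 1 to compound 2 (0.01 log units; within the scatter), the step from compound 3 to compound 4 is expected to be about as small, a 1.0-fold higher number from compound 3 to compound 4 (0.01 log units; within the scatter). Compound 4 is therefore estimated at 1800 nM, with a likely range from 900 nM to 3600 nM.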

Compound 4, half-maximal inhibitory concentration: 4170 nM
For compound 4 the middle estimate is 2.3-fold (0.36 log units) below the measured one; the whole stated range lies below it.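

In this assay, replacing methoxy with (oxolan-3-yl)oxy gave a 2.4-fold higher number from compound 3 to compound 4 (0.38 log units; beyond the scatter), a real step on this core, whereas the same replacement left the number unchanged within the scatter on the other core. Set side by side, the two steps do not differ by more than the scatter expected of two such steps: the same change on two cores in this assay, a 1.0-fold higher number (0.01 log units; within the scatter) from compound 1 to compound 2 and a 2.4-fold higher number (0.38 log units; beyond the scatter) from compound 3 to compound 4, 2.3-fold (0.37 log units) apart, within the scatter of two such steps. Among these compounds, this shows no clear dependence on the core, but it does not prove that the change carries over unchanged, as only one pair on each core is available.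

The compounds shown leave open how a longer chain on that oxygen, such as 2-methoxyethyl, would behave on either core. They also leave open whether a cyclic amine such as morpholine, in place of the dimethylamino group, would alter the step.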